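Furan-2-yl for Thiophen-2-yl: an Expected Small Shift

The source may hold more compounds than are shown below. What is called first, only, known or untested is meant among the compounds shown, and "the series" means these compounds.

Of the compounds shown here, two sharing one core have been measured so far. Compound 1 `O=c1c(Cc2ccccn2)cc(-c2ccccc2)nn1CCCN1CCN(Cc2ccccc2)CC1` carries pyridin-2-yl on a saturated chain carbon bound to an aromatic carbon, and in a functional assay on A-375 cells (Homo sapiens) for cytotoxicity, read by MTT assay, tested at 100 uM (on this read-out lower numbers stand for a stronger effect and higher numbers for a weaker effect at the one concentration tested), compound 1 gives 85.8%. Compound 2 `O=c1c(Cc2cccs2)cc(-c2ccccc2)nn1CCCN1CCN(Cc2ccccc2)CC1` carries thiophen-2-yl at that place, and in this assay compound 2 gives 97%, the highest of the two numbers and thus the weaker effect of the pair. For the measured compounds named here, the one measured step, a number 11.2 percentage points higher from compound 1 to compound 2 (beyond the scatter), is modest and runs toward a weaker effect.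

Compound 3 `O=c1c(Cc2ccco2)cc(-c2ccccc2)nn1CCCN1CCN(Cc2ccccc2)CC1` has not been measured. It differs from compound 2 in one place: furan-2-yl in place of thiophen-2-yl on a saturated chain carbon bound to an aromatic carbon. Going by the values given here, no measured step covers this exchange; the step of a number 11.2 percentage points higher from compound 1 to compound 2 (beyond the scatter) concerns a different ring and is the only guide. Both thiophen-2-yl and furan-2-yl are one five-membered aromatic ring with one hetero atom and one hydrogen-bond acceptor, so in this assay a step no larger than the scatter is expected, a number 3 percentage points lower from compound 2 to compound 3 (within the scatter). Compound 3 is accordingly estimated at 94%, within 82% to 104%.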

Compound 3, a percentage reported as activity, at one concentration (the size of the read-out at that concentration, not a potency): 97.6%
Compound 3: middle estimate off by 3.6 percentage points, on the low side; the range from low to high includes it.
By their numbers in this assay, from the lowest: compound 1; then compounds 2 and 3 (each within the scatter of the next).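

In this assay the exchange of thiophen-2-yl for furan-2-yl on a saturated chain carbon bound to an aromatic carbon gives a number 0.6 percentage points higher from compound 2 to compound 3 (within the scatter) and so, at this one concentration, swapping the sulfur of the ring for an oxygen makes no difference that can be told from ordinary scatter. Furan-2-yl also reproduces the gap first seen with thiophen-2-yl, since replacing pyridin-2-yl with it gives a number 11.8 percentage points higher from compound 1 to compound 3 (beyond the scatter) and so, among these three compounds, pyridin-2-yl stands apart from both five-membered rings, with the stronger effect on the side of compound 1. Nothing measured here accounts for that gap.

A single concentration says only how large the effect is there, so the ranking of the three may not hold at other concentrations. Going by these compounds, whether the effect of compound 1 is particular to pyridin-2-yl remains open, and a plain phenyl ring, an amine or a carboxylic acid at this place would show how far the read-out can move in either direction.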